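The compounds below may be only part of what the source reports. "The series", "measured", "known", "first", "only" and "open" are said of these compounds alone.

Measured in a functional assay on MCF7 cells (Homo sapiens) for inhibition, read by sulforhodamine B assay; a lower number here means a stronger inhibitor, a higher number a weaker inhibitor:
- compound 1 `O=C1C(Nc2ccc(Br)cc2)=CC(=O)c2c1nc1n2[C@H]2OC[C@@H](O)[C@H]2OC1`: 4330 nM
- compound 2 `Cc1ccc(NC2=CC(=O)c3c(nc4n3[C@H]3OC[C@@H](O)[C@H]3OC4)C2=O)cc1`: > 4000 nM
- compound 3 `O=C1C(NC2CC2)=CC(=O)c2c1nc1n2[C@H]2OC[C@@H](O)[C@H]2OC1`: > 16000 nM

Compound 3 gives > 16000 nM, which is a limit and not a number. Compound 2 gives > 4000 nM, which is also a limit. Only compound 1 has a numerical value here, so compound 3 can be placed only through its limit.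

Compound 4 `O=C1C(Nc2cccc(Cl)c2)=CC(=O)c2c1nc1n2[C@H]2OC[C@@H](O)[C@H]2OC1` keeps the shared core and has 3-chlorophenyl in place of cyclopropyl on an amine nitrogen.

The closest measured change runs the opposite way: an at least 3.6-fold higher number from compound 1 to compound 3 (0.56 log units; beyond the scatter). The other steps give no size: a step that the two limits leave unreadable from compound 2 to compound 3 and a step that the limit leaves unreadable from compound 1 to compound 2. Going by the values given here, the single readable step therefore carries the expectation, and compound 2 neither supports nor contradicts it.

A move towards a lower number in this assay is expected, of at least modest size: an at least 3.5-fold lower number from compound 3 to compound 4 (0.55 log units; beyond the scatter). For compound 4 the estimated value is 4500 nM, with an expected range of 1500 nM to 14000 nM.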

Compound 4, half-maximal inhibitory concentration: 2970 nM
Compound 4: middle estimate off by 1.5-fold (0.18 log units), on the high side, and the stated range covers the measured number.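

On the amine nitrogen, cyclopropyl leaves only a limit: compound 3 gives > 16000 nM, which is a limit and not a number. In this assay, 3-chlorophenyl in its place gives an at least 5.3-fold lower number from compound 3 to compound 4 (0.73 log units; beyond the scatter), so a second phenyl group bearing a halogen, at a different ring position from the 4-bromophenyl of compound 1, also gives a measured number. The 3-chlorophenyl group is not separated from 4-bromophenyl, with a 1.5-fold lower number from compound 1 to compound 4 (0.16 log units; within the scatter), nor from 4-methylphenyl, with an at least 1.3-fold lower number from compound 2 to compound 4 (0.12 log units; that floor lies within the scatter).

From the compounds shown here alone, compound 2 gives > 4000 nM, also a limit, so its true place stays open. Also open, going by these compounds, is what an unsubstituted phenyl, a benzyl or a 3-methoxyphenyl group on the same nitrogen would give, and whether any of them would separate from 3-chlorophenyl.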